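The source may report more compounds than this note shows. Statements on the series, on what has been measured and on what is new or still open speak of the compounds shown alone.

Going by the values given here, in an ADME assay on HepG2 cells (Homo sapiens) for cytotoxicity, read by MTT assay, with a stated time of 72 h (a lower number here means that less compound is tolerated, a higher number that more compound is tolerated), compound 3 `O=[N+]([O-])c1c(CS(=O)(=O)c2ccccc2)nc2c(-c3ccccc3CO)cc(Cl)cn12` gives 88000 nM, the only exact number among the measured compounds. Compound 1 `O=[N+]([O-])c1c(CS(=O)(=O)c2ccccc2)nc2c(-c3ccc(Cl)cc3)cc(Cl)cn12` reads > 3900 nM, which is a limit and not a number. Compound 2 `O=Cc1ccc(-c2cc(Cl)cn3c([N+](=O)[O-])c(CS(=O)(=O)c4ccccc4)nc23)cc1` reads > 31200 nM, which is also a limit.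

The next compound, compound 4 `O=[N+]([O-])c1c(CS(=O)(=O)c2ccccc2)nc2c(-c3ccc(F)cc3F)cc(Cl)cn12`, differs from compound 3 by a single swap: 2,4-difluorophenyl in place of 2-(hydroxymethyl)phenyl on an aromatic carbon. Two measured comparisons bear on this swap, yet neither gives a size: the data show a step that the limit leaves unreadable from compound 1 to compound 3, and also a step that the limit leaves unreadable from compound 2 to compound 3. The guide is therefore only resemblance, and a weak one: compound 4 carries a halogen-bearing phenyl group, as compound 1 does, and no longer has the hydroxymethyl group of compound 3.

A move toward a lower number is expected, with an estimated 3.5-fold lower number from compound 3 to compound 4 (0.55 log units; beyond the scatter). this assay may well report only a limit again. Compound 4 is estimated at 25000 nM, with an expected range from 5000 nM to 90000 nM.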

Compound 4, half-maximal cytotoxic concentration: > 7800 nM
Compound 4 ended at the assay's limit; the forecaster's own chance of this, stated with the estimate: 55%; the middle value lies beyond the limit too.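

In this assay compound 4 gives > 7800 nM, which is a limit and not a number, so its steps from compound 1, compound 2 and compound 3 cannot be read. Still open, as far as these compounds go, is how much of compound 1, compound 2 or compound 4 is actually tolerated compared with compound 3.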